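This account rests on a few compounds, and the source may have more. Where it says the series, first, only, none or still open, it means among the compounds named here.

Compound 1, `COc1cc(-n2cnc3ccc(-c4ccc(C(F)(F)F)cc4)cc32)cc(OC)c1OC`, is the point of departure. For the measured compounds named here, in a functional assay on MCF7 cells (Homo sapiens) for antiproliferative activity, read by MTT assay, with a stated time of 72 h (on this read-out lower numbers stand for stronger inhibition and higher numbers for weaker inhibition), compound 1 gives 760 nM, the second highest of the three numbers measured so far. Compound 3, `COc1cc(-n2cnc3ccc(-c4cccc(C)c4)cc32)cc(OC)c1OC`, gives 360 nM, while compound 2, `COc1cc(-n2cnc3ccc(-c4ccccc4)cc32)cc(OC)c1OC`, gives 2290 nM. The steps from compound 1 are a 2.1-fold lower number from compound 1 to compound 3 (0.32 log units; beyond the scatter) and a 3.0-fold higher number from compound 1 to compound 2 (0.48 log units; beyond the scatter), both beyond the scatter, and the third step is a 6.4-fold lower number from compound 2 to compound 3 (0.80 log units; beyond the scatter).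

Compound 4, `COc1cc(-n2cnc3ccc(-c4ccc(F)cc4)cc32)cc(OC)c1OC`, has not yet been measured. Its difference from compound 1 is fluoro in place of trifluoromethyl on an aromatic carbon. The measured step that bears most directly on this is a 3.0-fold higher number from compound 1 to compound 2 (0.48 log units; beyond the scatter), where the same trifluoromethyl gave way to hydrogen at the same aromatic carbon and the number rose by a modest amount. The step of a 6.4-fold lower number from compound 2 to compound 3 (0.80 log units; beyond the scatter) concerns methyl in place of hydrogen at another place and speaks less to this change. Fluoro keeps one heavy atom where trifluoromethyl had four, so the expected outcome lies between no change and the rise seen from compound 1 to compound 2: a modest increase in the number, near the edge of the scatter. Compound 4 is therefore expected to give 1300 nM, within a range of 600 nM to 2800 nM. That estimate corresponds to an expected step of a 1.7-fold higher number from compound 1 to compound 4 (0.23 log units; within the scatter).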

Compound 4, half-maximal inhibitory concentration: 1770 nM
Estimate against measurement, compound 4: 1.4-fold (0.13 log units) below; the measured number falls inside the stated range.
By their numbers in this assay, from the lowest: compound 3; then compound 1; then compounds 4 and 2 (each within the scatter of the next).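

Fluoro does not do what trifluoromethyl does on this aromatic carbon in this assay: replacing one with the other gives a clear loss (a 2.3-fold higher number from compound 1 to compound 4 (0.37 log units; beyond the scatter)), so the lower number of compound 1 does not follow from simply having fluorine at this position. Fluoro and hydrogen cannot be told apart here (a 1.3-fold lower number from compound 2 to compound 4 (0.11 log units; within the scatter)), which means that, among these three groups, only trifluoromethyl stands out from the unsubstituted phenyl of compound 2. The 3-methylphenyl group of compound 3 also keeps a clear lead over the 4-fluorophenyl group (a 4.9-fold higher number from compound 3 to compound 4 (0.69 log units; beyond the scatter)), but nothing measured here explains why these groups differ.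

The compounds shown leave open how other groups would behave on this same carbon, such as a methyl, a methoxy, an amine or a carboxylic acid, and whether any would match trifluoromethyl. They also leave open what fluoro or trifluoromethyl would do at the place that methyl holds in compound 3, and so whether the place or the group matters more.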